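This account rests on a few compounds, and the source may have more. Where it says the series, first, only, none or still open, it means among the compounds named here.

Measured compounds:
compound 1 `Cn1c(=O)c(=O)n(C2CCCC2)c2nc(N/N=C/c3ccc(S(C)(=O)=O)cc3)ncc21` with 86600 nM
compound 2 `Cc1cc(C)c(/C=N/Nc2ncc3c(n2)n(C2CCCC2)c(=O)c(=O)n3C)c(C)c1` with 7920 nM
compound 3 `Cn1c(=O)c(=O)n(C2CCCC2)c2nc(N/N=C/c3cc(C(F)(F)F)cc(C(F)(F)F)c3)ncc21` with 4360 nM

All three share one core and differ only in the aryl group on a carbon with a double bond to nitrogen. In a functional assay on HCT-116 cells (Homo sapiens) for antiproliferative activity, read by MTT assay (on this read-out lower numbers stand for stronger inhibition and higher numbers for weaker inhibition), compound 2 gives 7920 nM, the second highest of the three numbers. Its nearest neighbour is compound 3, whose value of 4360 nM lies within the scatter of that of compound 2, so no order between these two can be claimed. Going by the values given here, the furthest is compound 1, at 86600 nM; the one measured step, an 11-fold lower number from compound 1 to compound 2 (1.04 log units; beyond the scatter), is large and beyond the scatter.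

The new compound 4 `Cn1c(=O)c(=O)n(C2CCCC2)c2nc(N/N=C/c3cc([N+](=O)[O-])ccc3Cl)ncc21` has not yet been measured. Its change from compound 2 is 2-chloro-5-nitrophenyl in place of 2,4,6-trimethylphenyl on a carbon with a double bond to nitrogen. Among the compounds with values here, only the step from compound 1 to compound 2 bears on this change, and it shows that the aryl group here can move the number a long way. Compound 3 shows that a second departure from the trimethylphenyl left the number within the scatter of compound 2. Within the data shown here, with no closer precedent, compound 4 is expected to land near compound 2, with a 1.1-fold lower number from compound 2 to compound 4 (0.05 log units; within the scatter) estimated to stay within the scatter. The estimate for compound 4 is 7000 nM, with a range from 2500 nM to 25000 nM.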

Compound 4, half-maximal inhibitory concentration: 5610 nM
Estimate against measurement, compound 4: 1.2-fold (0.10 log units) above, and the stated range covers the measured number.
By their numbers in this assay, from the lowest: compounds 3, 4 and 2 (each within the scatter of the next); then compound 1.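

In this assay, the step of a 1.4-fold lower number from compound 2 to compound 4 (0.15 log units; within the scatter) lies within the scatter, so replacing 2,4,6-trimethylphenyl with 2-chloro-5-nitrophenyl on this carbon gives no order between the two compounds, even though the two aryl groups share no substituent. The step of a 15-fold lower number from compound 1 to compound 4 (1.19 log units; beyond the scatter) is large and beyond the scatter, which leaves compound 1, at 86600 nM, apart from compounds 2, 3 and 4, whose aryl groups carry methyl, trifluoromethyl, or chloro and nitro substituents and whose numbers run within the scatter of one another. Nothing available here explains why the 4-(methylsulfonyl)phenyl compound stands apart from the other three.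

The compounds shown leave open whether an aryl group bearing an amine or a carboxylic acid, or a plain phenyl ring, would fall with compounds 2, 3 and 4 or with compound 1. They also leave open whether any group at this position can take the number beyond the scatter on the low side of compound 3. Compound 3 gives 4360 nM.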